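Amide ring swap: thiophen-3-yl to 1-methyl-1H-pyrazol-5-yl

The source may report more compounds than this note shows. Statements on the series, on what has been measured and on what is new or still open speak of the compounds shown alone.

Compound 1 `CCCCCCCCCCCC[C@@H](O)[C@H]1CC[C@H]([C@H](O)CCCCCCCCCCNC(=O)c2ccoc2)O1`: 191 nM
Compound 2 `CCCCCCCCCCCC[C@@H](O)[C@H]1CC[C@H]([C@H](O)CCCCCCCCCCNC(=O)c2cncs2)O1`: 219 nM
Compound 3 `CCCCCCCCCCCC[C@@H](O)[C@H]1CC[C@H]([C@H](O)CCCCCCCCCCNC(=O)c2ccsc2)O1`: 170 nM

All three compounds were measured in a functional assay on DMS-114 cells (Homo sapiens) for inhibition, read by colorimetric assay and sulforhodamine B assay, with a stated time of 48 h; a lower number here means a stronger inhibitor of growth, a higher number a weaker inhibitor of growth. Compound 3 gives 170 nM and cannot be separated from the other two, with a 1.1-fold lower number from compound 1 to compound 3 (0.05 log units; within the scatter) and a 1.3-fold lower number from compound 2 to compound 3 (0.11 log units; within the scatter).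

Compound 4 `CCCCCCCCCCCC[C@@H](O)[C@H]1CC[C@H]([C@H](O)CCCCCCCCCCNC(=O)c2ccnn2C)O1` is still to be measured in this assay. The change is 1-methyl-1H-pyrazol-5-yl in place of thiophen-3-yl on a carbonyl carbon. It sits on a carbonyl carbon whose other neighbour is an amide-type nitrogen, the place varied in all the measured compounds. The remaining measured step at this place is a 1.1-fold higher number from compound 1 to compound 2 (0.06 log units; within the scatter). All three steps are small, so no step beyond the scatter is expected in this assay. Going by the values given here, no measured compound carries the 1-methyl-1H-pyrazol-5-yl group, which leaves a somewhat higher number as the more likely direction of any departure and keeps the range wide.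

The expected step is a 1.4-fold higher number from compound 3 to compound 4 (0.13 log units; within the scatter). Compound 4 is estimated at 230 nM, with an expected range of 110 nM to 520 nM.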

Compound 4, concentration for 50% growth inhibition: 10 nM
Beside the measured number, compound 4's estimate is 23-fold (1.36 log units) above it; the measured number lies below the stated range.
By their numbers in this assay, from the lowest: compound 4; then compounds 3, 1 and 2 (each within the scatter of the next).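

Up to now, the amide ring at this place looked interchangeable in this assay: furan-3-yl, 1,3-thiazol-5-yl and thiophen-3-yl all stayed within the scatter of one another. The 1-methyl-1H-pyrazol-5-yl group breaks that picture, with a 17-fold lower number from compound 3 to compound 4 (1.23 log units; beyond the scatter) and a 22-fold lower number from compound 2 to compound 4 (1.34 log units; beyond the scatter) and also a 19-fold lower number from compound 1 to compound 4 (1.28 log units; beyond the scatter), so the ring on this carbonyl carbon can strongly change growth inhibition and compound 4 stands clearly apart from the other three. No measured evidence is available to account for a step of this size.

A pyrazole without the methyl group and a 1-methylimidazole would help show whether the step follows the methyl group, the ring nitrogens or their arrangement. As far as these compounds go, whether the step carries over to cells other than those of this assay also stays open.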